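A few compounds are considered here, and "the series" means these few. Any claim that something is new, unique, unknown or untested is made for them only; others in the source may bear on it.

Compound 1 `COc1cccc2c1nc(-c1c(F)cccc1F)n2Cc1c(F)cccc1F`: 44.3 uM
Compound 2 `Oc1cccc2c1nc(-c1c(F)cccc1F)n2Cc1c(F)cccc1F`: > 100 uM

In a toxicity assay on CCRF-CEM cells (Homo sapiens) for cytotoxicity (on this read-out lower numbers stand for higher toxicity in this test and higher numbers for lower toxicity in this test), compound 2 gives > 100 uM, which is a limit of the assay and not a number. It stands at the edge of the scale: the limit of > 100 uM in this assay, at which 1 of the 2 values shown sits. Among the measured compounds shown here, the one measured step is an at least 2.2-fold higher number from compound 1 to compound 2 (0.35 log units; beyond the scatter), with hydrogen in place of methyl on an oxygen on an aromatic ring.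

Compound 3 `Nc1cccc2c1nc(-c1c(F)cccc1F)n2Cc1c(F)cccc1F` differs from compound 2 by amino in place of hydroxy on an aromatic carbon. For the measured compounds named here, no measured step makes this exchange, so the earlier step bears on it only loosely. A modest move toward a lower number is expected in this assay, since compound 1 at 44.3 uM shows that this core can give a number. The expected change is an at least 1.4-fold lower number from compound 2 to compound 3 (0.15 log units; that floor lies within the scatter). For compound 3 the estimated value is 70 uM, with an expected range of 25 uM to 150 uM.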

Compound 3, half-maximal toxic concentration: 26.3 uM
The estimate for compound 3 lay 2.7-fold (0.43 log units) above the measured number, and the stated range covers the measured number.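

In this assay, amino in place of hydroxy on this aromatic carbon gives an at least 3.8-fold lower number from compound 2 to compound 3 (0.58 log units; beyond the scatter), even though the two groups have the same counts of hydrogen-bond donors and acceptors. Amino and methoxy on this carbon are not told apart, as the step is a 1.7-fold lower number from compound 1 to compound 3 (0.23 log units; within the scatter), so among these three groups only hydroxy stands apart. Compound 2 gives a limit and not a number, so the full size of its steps stays unknown: the limit of > 100 uM in this assay, at which 1 of the 3 values shown sits.

The compounds shown leave open whether a carboxylic acid, an ethoxy group or a plain hydrogen on this carbon would fall with hydroxy or with amino and methoxy. They also leave open whether these exchanges would read the same on another aromatic carbon of the shared core.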